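The source may hold more compounds than are shown below. What is called first, only, known or untested is meant among the compounds shown, and "the series" means these compounds.

Measured compounds:
compound 1 `CC/C=C\C(=O)Nc1cc(Nc2nc(C)cc(-c3cn(C)c4ccccc34)n2)c(OC)cc1N(C)CCN(C)C` — 2050 nM
compound 2 `COc1cc(N(C)CCN(C)C)c(NC(=O)/C=C\C(C)C)cc1Nc1nc(C)cc(-c2cn(C)c3ccccc23)n1` — 3550 nM
compound 3 `CCC/C=C\C(=O)Nc1cc(Nc2nc(C)cc(-c3cn(C)c4ccccc34)n2)c(OC)cc1N(C)CCN(C)C` — 365 nM

All three numbers come from a functional assay on HepG2 cells (Homo sapiens) for antiproliferative activity, read by MTT assay, with a stated time of 72 h; on this read-out lower numbers stand for stronger inhibition and higher numbers for weaker inhibition. Compound 3 gives the lowest number of the three; the step of a 5.6-fold lower number from compound 1 to compound 3 (0.75 log units; beyond the scatter) and the step of a 9.7-fold lower number from compound 2 to compound 3 (0.99 log units; beyond the scatter) both lie beyond the scatter, so compound 3 stands apart on this read-out. The step of a 1.7-fold higher number from compound 1 to compound 2 (0.24 log units; within the scatter) stays within the scatter.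

Compound 4 `CCC/C=C\C(=O)Nc1cc(Nc2nc(C)cc(-c3cn(C)c4ccc(F)cc34)n2)c(OC)cc1N(C)CCN(C)C` keeps the whole of compound 3 and differs in one place: fluoro in place of hydrogen on an aromatic carbon. Going by the values given here, none of the measured steps touches this part of the molecule; all three concern the chain carried by the amide, and the ring that changes here is the same in compound 1, compound 2 and compound 3. Among the compounds with values here, there is therefore no measured step that bears on this change, and no ground in the numbers for expecting a shift beyond the scatter in either direction in this assay.

The expectation for compound 4 is thus a number close to that of compound 3, with a step of a 1.0-fold lower number from compound 3 to compound 4 (0.02 log units; within the scatter). Compound 4 is estimated at 350 nM, with a range from 120 nM to 1100 nM.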

Compound 4, half-maximal inhibitory concentration: 12100 nM
Compound 4: middle estimate off by 35-fold (1.54 log units), on the low side, outside the stated range (above it).
By their numbers in this assay, from the lowest: compound 3; then compounds 1 and 2 (each within the scatter of the next); then compound 4.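

In this assay, going by these compounds alone, the change from 1-methyl-1H-indol-3-yl to 5-fluoro-1-methyl-1H-indol-3-yl gives a 33-fold higher number from compound 3 to compound 4 (1.52 log units; beyond the scatter) and is the largest step so far, although only a single fluoro enters in place of hydrogen. The earlier steps all lay in the chain carried by the amide, so this is the first sign that the number also responds to a change on the aromatic carbon of the six-membered aromatic ring, and here a small substitution outweighs each of the chain changes shown. Nothing available bears on what lies behind this rise.

On these data alone, it remains open whether the loss belongs to fluoro alone or to substitution on this carbon more generally, and what a chloro, a methoxy or an amino group in the same place would give. Also open, as far as these compounds go, is whether the same change would have a similar effect with the amide chains of compound 1 and compound 2, or on the other aromatic carbons of that ring.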